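The source may hold more compounds than are shown below. What is called first, only, known or untested is meant among the compounds shown, and "the series" means these compounds.

Among the compounds with values here, in a functional assay on HCT-116 cells (Homo sapiens) for inhibition, read by MTT assay, with a stated time of 48 h (a higher number here means a weaker inhibitor, a lower number a stronger inhibitor), compound 1 (`COc1ccc(C/N=C2\NC(=O)/C(=C3\CCNC(=O)c4[nH]ccc43)S2)cc1`) gives 19400 nM, and it is the only compound tested so far that gives an actual number. Its two relatives reach only limits of the assay. Compound 2 (`O=C1N/C(=N\Cc2ccccc2Cl)S/C1=C1/CCNC(=O)c2[nH]ccc21`) gives > 50000 nM, which is a limit. Compound 3 (`CC(C)(C)c1ccc(C/N=C2\NC(=O)/C(=C3\CCNC(=O)c4[nH]ccc43)S2)cc1`) gives > 100000 nM, which is also a limit.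

The next compound, compound 4 (`COc1ccc(C/N=C2\NC(=O)/C(=C3\CCNC(=O)c4c3ccn4C)S2)cc1`), keeps the 4-methoxyphenyl group of compound 1 and changes the core instead: methyl in place of hydrogen on an aromatic nitrogen. A methyl takes the place of hydrogen on an aromatic nitrogen.

Two measured steps offer some guidance: an at least 2.5-fold higher number from compound 1 to compound 2 (0.41 log units; beyond the scatter) and an at least 5.1-fold higher number from compound 1 to compound 3 (0.71 log units; beyond the scatter). Both are minimum sizes, set by the limits, and both point towards weaker inhibition. Within the data shown here, neither touches the aromatic nitrogen, so they are only indirect guides, and no measured pair tests this change directly.

Since both changes made to compound 1 so far, an at least 2.5-fold higher number from compound 1 to compound 2 (0.41 log units; beyond the scatter) and an at least 5.1-fold higher number from compound 1 to compound 3 (0.71 log units; beyond the scatter), raised the number, a modest rise is the cautious expectation in this assay. The expected step is a 2.1-fold higher number from compound 1 to compound 4 (0.31 log units; beyond the scatter), towards weaker inhibition. For compound 4 the estimated value is 40000 nM, with an expected range of 12000 nM to 100000 nM.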

Compound 4, half-maximal inhibitory concentration: > 100000 nM
Compound 4 gave a limit, no number; the forecaster's own chance of this, stated with the estimate: 35%; middle value at least 2.5-fold (0.39 log units) away from the limit.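

Within the data shown here, compounds 2 and 3 changed only the group on the chain, so compound 4 is the first to show that the shared core also matters in this assay: keeping the 4-methoxyphenyl group and placing methyl in place of hydrogen on the aromatic nitrogen gives an at least 5.1-fold higher number from compound 1 to compound 4 (0.71 log units; beyond the scatter). Compound 4 gives > 100000 nM, which is a limit of the assay and not a number. The change adds just 1 heavy atom, yet it is enough to lose the only measured number in this small set, and the step is only a minimum size, set by the ceiling the values reach: the limit of > 100000 nM in this assay, at which 2 of the 4 values shown sit.

On these data alone, how far compound 4 truly lies from compound 1 stays open, as does whether the loss follows from removing the hydrogen on this nitrogen or from adding the methyl. Also unresolved is how a longer chain such as ethyl, or an amine or a carboxylic acid carried on a short chain at this nitrogen, would behave in this assay.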